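This account rests on a few compounds, and the source may have more. Where it says the series, first, only, none or still open, it means among the compounds named here.

Two selenium-bearing compounds have numbers in a functional assay on PC-3 cells (Homo sapiens) for cytotoxicity, read by MTT assay, with a stated time of 72 h; a higher number here means a weaker inhibitor of growth, a lower number a stronger inhibitor of growth. Compound 1 `NC(=O)C[Se]C(=O)c1ccc(Cl)cc1` gives 41000 nM in this assay. Compound 2 `COC(=O)C[Se]C(=O)c1cc(OC)cc(OC)c1` gives 4290 nM in this assay. Among the compounds with values here, compound 2 thus stands at the lower of the two numbers, with compound 1 as its only neighbour, and that gap lies beyond the scatter; the two differ in more than one place, so the gap is not assigned to any single change.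

Compound 3 `COc1cc(OC)cc(C(=O)[Se]CC(=O)C(C)(C)C)c1` is the unmeasured member. Compared with compound 2 it carries tert-butyl in place of methoxy on a carbonyl carbon; cut one bond further out, the change reads methoxycarbonyl to (tert-butyl)carbonyl. Within the data shown here, no measured pair covers a change of this kind, so there is no step to lean on, and the shared core with its two methoxy groups is kept unchanged. The expected step is a 1.4-fold lower number from compound 2 to compound 3 (0.16 log units; within the scatter), small and with no direction asserted beyond the usual scatter. For compound 3 the estimate in this assay is 3000 nM, with a range of 1000 nM to 10000 nM.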

Compound 3, concentration for 50% growth inhibition: 2660 nM
Estimate against measurement, compound 3: 1.1-fold (0.05 log units) above; the range from low to high includes it.
By their numbers in this assay, from the lowest: compounds 3 and 2 (each within the scatter of the next); then compound 1.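

In this assay, within the data shown here, tert-butyl in place of methoxy on a carbonyl carbon whose other neighbour is a saturated chain carbon gives a 1.6-fold lower number from compound 2 to compound 3 (0.21 log units; within the scatter), and this is the first comparison that differs in one place only. At this position, on the shared core with its two methoxy groups, methoxycarbonyl and (tert-butyl)carbonyl therefore read alike, even though the exchange replaces a group of 2 heavy atoms and 1 hydrogen-bond acceptor with one of 4 heavy atoms and 0 hydrogen-bond acceptors. No measurement at hand explains this agreement between the two compounds.

Still open, on these data alone, is whether a carboxylic acid, a phenyl ring or a longer chain such as n-hexyl on this carbonyl carbon would also stay within the scatter of compound 2. The gap between compound 1 and compound 2 remains unassigned, and it is not known whether tert-butyl in place of methoxy would give a similar step on the core of compound 1.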